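From phenylsulfonyl to (pyridin-3-yl)carbonyl on the ring nitrogen

This account rests on a few compounds, and the source may have more. Where it says the series, first, only, none or still open, it means among the compounds named here.

In a physicochemical assay for lipophilicity, measured as octanol-water partition, at pH 7.4 (a higher number here means a more lipophilic compound, a lower number a more polar compound), compound 1 `Cc1ccc2[nH]c(C(=O)N[C@H]3CN(S(=O)(=O)c4ccnnc4)C[C@@H]3C(=O)NCCN(C)C)cc2c1` gives 0.7, while compound 2 `Cc1ccc2[nH]c(C(=O)N[C@H]3CCN(S(=O)(=O)c4ccccc4)C[C@@H]3C(=O)NCCN(C)C)cc2c1` gives 2.2, the higher of the two numbers and beyond the scatter. Compound 3 `Cc1ccc2[nH]c(C(=O)N[C@H]3CCN(C(=O)c4cccnc4)C[C@@H]3C(=O)NCCN(C)C)cc2c1` carries (pyridin-3-yl)carbonyl in place of phenylsulfonyl on an amine nitrogen in a ring. Among the measured compounds shown here, no measured pair differs in one place only, so the expectation remains a rough one. A fall beyond the scatter is expected in this assay, estimated as a number 0.90 log units lower from compound 2 to compound 3 (beyond the scatter). Compound 3 is expected at 1.3, within an estimated range of 0.7 to 1.9.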

Compound 3, distribution coefficient: 0.7
Compound 3: middle estimate off by 0.60 log units, on the high side; the range from low to high includes it.
By their numbers in this assay, from the lowest: compounds 1 and 3 (each within the scatter of the next); then compound 2.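

On the amine nitrogen in a ring, (pyridin-3-yl)carbonyl in place of phenylsulfonyl gives, in this assay, a number 1.50 log units lower from compound 2 to compound 3 (beyond the scatter), the only step shown in which the rest of the molecule stays the same. It shows that this position alone can move the number by a large step, although two things change together here: the linking sulfonyl becomes a carbonyl, and the carbon-only aromatic ring gains a hetero atom. Nothing available explains the step. Which of these two changes carries the step remains open. Benzoyl or (pyridin-3-yl)sulfonyl on the same nitrogen would separate them.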